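The source may report more compounds than this note shows. Statements on the series, on what has been measured and on what is new or still open speak of the compounds shown alone.

Of the compounds shown here, three that share one core have been measured in an ADME assay on HepG2 cells (Homo sapiens) for cytotoxicity, read by luminescence, CellTiter-Glo and ATP content, with a stated time of 72 h; a lower number here means that less compound is needed, a higher number that more compound is needed for the effect. Compound 1 `Fc1ccc(-c2ccc3c(NCCCNCc4ccco4)ccnc3c2)cc1` gives 7760 nM. Compound 2 `COc1cccc(Oc2ccc3c(NCCCNCc4ccco4)ccnc3c2)c1` gives 15500 nM, and the step of a 2.0-fold higher number from compound 1 to compound 2 (0.30 log units; within the scatter) lies within the scatter. Compound 3 `CC(C)(C)c1ccc(-c2ccc3c(NCCCNCc4ccco4)ccnc3c2)cc1` gives 3150 nM, the lowest of the three numbers; the step of a 2.5-fold lower number from compound 1 to compound 3 (0.39 log units; beyond the scatter) and the step of a 4.9-fold lower number from compound 2 to compound 3 (0.69 log units; beyond the scatter) both set it apart from the other two.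

Compound 4 `COc1ccc(Oc2ccc3c(NCCCNCc4ccco4)ccnc3c2)cc1` has not yet been measured. It differs from compound 3 in one place: 4-methoxyphenoxy in place of 4-(tert-butyl)phenyl on an aromatic carbon. The group that leaves is the one that entered in the step of a 4.9-fold lower number from compound 2 to compound 3 (0.69 log units; beyond the scatter), and the group that enters is close in kind to the 3-methoxyphenoxy of compound 2. That step therefore bears most on the question, and read in reverse it suggests that the number for compound 4 should rise back toward the value of compound 2. The step of a 4.1-fold higher number from compound 3 to compound 4 (0.62 log units; beyond the scatter) is the expected size of that rise. Compound 4 is estimated to give 13000 nM, within a range from 6000 nM to 30000 nM.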

Compound 4, half-maximal effective concentration: 5300 nM
For compound 4 the middle estimate is 2.5-fold (0.39 log units) above the measured one; the measured number lies below the stated range.
By their numbers in this assay, from the lowest: compounds 3, 4, 1 and 2 (each within the scatter of the next, the first and the last beyond it).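

In this assay, a phenoxy group at this place does not by itself set a compound apart: a 1.7-fold higher number from compound 3 to compound 4 (0.23 log units; within the scatter) and a 1.5-fold lower number from compound 1 to compound 4 (0.17 log units; within the scatter) both show that 4-methoxyphenoxy stays within the scatter of the two aryl groups joined directly to the shared core. What does matter is where the methoxy sits on the phenoxy ring, since moving it alone gives a 2.9-fold lower number from compound 2 to compound 4 (0.47 log units; beyond the scatter), a step beyond the scatter and the only new one of that kind. No measurement at hand gives a reason for this difference.

On these data alone, it remains open whether the sensitivity to the place of the methoxy extends to other groups on the phenoxy ring. As far as these compounds go, it is also open how an amine or a carboxylic acid on that ring would change the number.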